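The compounds below may be only part of what the source reports. "The series", "measured", "known", "first", "only" and "open" are said of these compounds alone.

In a functional assay on SK-OV-3 cells (Homo sapiens) for antiproliferative activity, read by MTT assay, with a stated time of 72 h (on this read-out lower numbers stand for stronger inhibition and higher numbers for weaker inhibition), compound 1 `O=C(CCc1cccc2c1B(O)OC2)Nc1cccc(-c2ccc(F)cc2)c1` gives 93 nM and compound 2 `O=C(CCc1cccc2c1B(O)OC2)Nc1cccc(-c2ccc(Cl)cc2)c1` gives 220 nM as the higher of the two numbers. Compound 3 `O=C(CCc1cccc2c1B(O)OC2)Nc1cccc(-c2ccc(C(F)(F)F)cc2)c1` carries trifluoromethyl in place of chloro on an aromatic carbon, para to a large group (trifluoromethyl in place of chloro on an aromatic carbon). Going by the values given here, the only measured step that bears on this change is modest (a 2.4-fold higher number from compound 1 to compound 2 (0.37 log units; beyond the scatter)), so a further small rise of about that size is expected in this assay with no trifluoromethyl value yet to test it. Compound 3 is estimated at 300 nM with an expected range of 110 nM to 800 nM on this read-out. The estimate means an expected step (a 1.4-fold higher number from compound 2 to compound 3 (0.13 log units; within the scatter)).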

Compound 3, half-maximal inhibitory concentration: 500 nM
Compound 3: middle estimate off by 1.7-fold (0.22 log units), on the low side; low and high end bracket the measured number.
By their numbers in this assay, from the lowest: compound 1; then compound 2; then compound 3.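

Trifluoromethyl in place of chloro at this position gives a 2.3-fold higher number from compound 2 to compound 3 (0.36 log units; beyond the scatter) in this assay and so the number keeps rising past chloro. Taken from fluoro, the same position shows a 5.4-fold higher number from compound 1 to compound 3 (0.73 log units; beyond the scatter) and the three compounds fall in one order, fluoro, chloro, trifluoromethyl, with none against it. Nothing shown here accounts for that order. From the compounds shown here alone, whether the order extends to other groups at this position stays open, such as a methoxy group, a nitrile or an amine. Also open, going by these compounds, is whether a plain hydrogen there would give a lower number than fluoro.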